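Replacing 3-Methylphenyl with 2-Methoxyphenyl: Foreseeing Compound 4

A few compounds are considered here, and "the series" means these few. Any claim that something is new, unique, unknown or untested is made for them only; others in the source may bear on it.

Compound 1 `Cc1cccc(-n2nncc2CN2C(=O)C3(C(C#N)=C(N)Oc4c3c3nc5ccccc5nc3c3ccccc43)c3ccccc32)c1` — in an ADME assay on HUVEC cells (Homo sapiens) for antiproliferative activity, read by MTT assay, with a stated time of 48 h (on this read-out lower numbers stand for stronger inhibition and higher numbers for weaker inhibition), compound 1 gives > 50000 nM, which is a limit of the assay.
Compound 2 `N#CC1=C(N)Oc2c(c3nc4ccccc4nc3c3ccccc23)C12C(=O)N(Cc1cnnn1-c1ccc(Br)cc1)c1ccccc12` — in this assay compound 2 gives > 50000 nM, again a limit of the assay.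
Compound 3 `Cc1cccc(-n2nncc2CN2C(=O)C3(C(C#N)=C(N)Oc4c(N)cc5nc6ccccc6nc5c43)c3ccccc32)c1` — in this assay compound 3 gives > 50000 nM, also a limit of the assay.

Compound 3 thus stands at the limit of the assay rather than at a number. All three values shown sit at that same limit (the limit of > 50000 nM in this assay, at which 3 of the 3 values shown sit). The change that leads to compound 4 `COc1ccccc1-n1nncc1CN1C(=O)C2(C(C#N)=C(N)Oc3c(N)cc4nc5ccccc5nc4c32)c2ccccc21` is 2-methoxyphenyl in place of 3-methylphenyl on an aromatic nitrogen. Going by the values given here, only one measured step touches the same position, the step that the two limits leave unreadable from compound 1 to compound 2, and the two limits leave its size unreadable. Among the compounds with values here, a swap of the aryl group on the aromatic nitrogen has therefore not been seen to move the read-out in either direction, and nothing among the measured compounds gives a basis for expecting compound 4 to leave the limit. Compound 4 is therefore expected to give 60000 nM, with a range from 20000 nM to 200000 nM. The step that this estimate means, a step that the limit leaves unreadable from compound 3 to compound 4, is expected to be none beyond the scatter, and the most likely outcome is that the assay again reports only a limit.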

Compound 4, half-maximal inhibitory concentration: > 50000 nM
Compound 4: no number, only a limit (the forecaster's own chance of this, stated with the estimate: 85%); the middle value does not contradict the limit.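

Compound 3 and compound 4 each give only a limit in this assay, so no step can be read between them, and 2-methoxyphenyl in place of 3-methylphenyl has no readable size. The values shown all stand at one point: the limit of > 50000 nM in this assay, at which 4 of the 4 values shown sit. The compounds shown leave open which change, if any, would yield a measurable number.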